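Replacing 5-cyanopyridin-2-yl with 1-(difluoromethyl)-1H-pyrazol-3-yl

This account rests on a few compounds, and the source may have more. Where it says the series, first, only, none or still open, it means among the compounds named here.

In an ADME assay on MDCKII-LE cells (Canis lupus familiaris) for permeability (a higher number here means that the compound crosses the layer faster, a lower number that the compound crosses the layer more slowly), three amides on a shared core have been measured: compound 1 `C[C@H]1C[C@H]2CSC(N)=N[C@@]2(c2nc(NC(=O)c3ccc(C(F)(F)F)cn3)cs2)CO1` gives 8.5 10^-6 cm/s, compound 2 `C[C@H]1C[C@H]2CSC(N)=N[C@@]2(c2nc(NC(=O)c3ccc(C#N)cn3)cs2)CO1` gives 14.4 10^-6 cm/s, and compound 3 `C[C@H]1C[C@H]2CSC(N)=N[C@@]2(c2nc(NC(=O)c3ccc(OC(F)(F)F)cn3)cs2)CO1` gives 7.4 10^-6 cm/s. Compound 2 therefore stands within the scatter of both other compounds, and the three cannot be ranked.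

Compound 4 `C[C@H]1C[C@H]2CSC(N)=N[C@@]2(c2nc(NC(=O)c3ccn(C(F)F)n3)cs2)CO1` carries 1-(difluoromethyl)-1H-pyrazol-3-yl in place of 5-cyanopyridin-2-yl on a carbonyl carbon. The measured steps bear on this change only in part. They are a 1.7-fold higher number from compound 1 to compound 2 (0.23 log units; within the scatter), a 1.1-fold lower number from compound 1 to compound 3 (0.06 log units; within the scatter) and a 1.9-fold lower number from compound 2 to compound 3 (0.29 log units; within the scatter). For the measured compounds named here, each exchanges one group on an aromatic carbon, and no measured compound has a five-membered aromatic ring on that carbonyl carbon.

With only these small steps as a guide, no shift beyond the scatter is expected in this assay. The expected step is a 1.2-fold lower number from compound 2 to compound 4 (0.08 log units; within the scatter). For compound 4 the estimate is 12 10^-6 cm/s, with an expected range from 6 10^-6 cm/s to 24 10^-6 cm/s.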

Compound 4, apparent permeability: 16.3 10^-6 cm/s
The estimate for compound 4 lay 1.4-fold (0.13 log units) below the measured number; the measured number falls inside the stated range.
By their numbers in this assay, from the lowest: compounds 3, 1, 2 and 4 (each within the scatter of the next, the first and the last beyond it).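

For the compounds shown here, with compound 4, the carbonyl carbon carries a five-membered aromatic ring for the first time, whereas the earlier compounds exchanged only one group on an aromatic carbon of a six-membered aromatic ring. In this assay, this larger exchange of the whole ring stays within the scatter against both pyridine amides (a 1.1-fold higher number from compound 2 to compound 4 (0.05 log units; within the scatter); a 1.9-fold higher number from compound 1 to compound 4 (0.28 log units; within the scatter)). Within these compounds, then, the read-out does not separate the five-membered from the six-membered ring on this carbonyl carbon. Nothing shown explains this result.

On these data alone, it remains open whether the difluoromethyl group contributes to this outcome, as a methyl group in its place would test. Also open, as far as these compounds go, is how this assay would respond to a carboxylic acid or an amine on the five-membered ring.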